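The compounds below may be only part of what the source reports. "The series", "measured", "known", "first", "only" and "open" are said of these compounds alone.

Of the compounds shown here, two of a shared core have been tested so far, and both carry a ring attached to one aromatic carbon of that core. Compound 1 `c1ccc2c(c1)CCN(c1ccnc(Nc3ccc(Oc4ncnc5ccsc45)cc3)n1)C2` was tested in a functional assay on MDA-MB-231 cells (Homo sapiens) for inhibition, read by MTT assay, with a stated time of 72 h, tested at 20 uM (on this read-out lower numbers stand for less inhibition and higher numbers for more inhibition at the one concentration tested (going by the name of the read-out)), and gave 15.4%. Compound 2 `c1cc(N2CCCC2)nc(Nc2ccc(Oc3ncnc4sccc34)cc2)n1`, in the same assay, gave 24.7%. Of the two numbers, compound 2 shows the higher reading, yet the gap between compound 2 and compound 1 lies within the usual scatter of this kind of measurement, so the two results cannot be told apart with confidence.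

The next compound, compound 3 `c1ccc2c(c1)CCN(c1ccnc(Nc3ccc(Oc4ncnc5sccc45)cc3)n1)C2`, is built from compound 2 by a single change: 1,2,3,4-tetrahydroisoquinolin-2-yl in place of pyrrolidin-1-yl on an aromatic carbon. Going by the values given here, no measured pair with exactly this change is available, so the expected effect rests only on what is known. Compound 1 carries the same entering group on its own core and gave 15.4%, which points toward a reading in a similar region. The step from compound 2 to compound 3 is therefore expected to be small, downward, and not beyond the scatter, a number 6.7 percentage points lower from compound 2 to compound 3 (within the scatter). In this assay compound 3 is expected to give about 18%, most likely between 5% and 33%.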

Compound 3, a percentage reported as inhibition, at one concentration (the size of the read-out at that concentration, not a potency): 26.8%
Compound 3: the middle estimate sits 8.8 percentage points below what was measured; low and high end bracket the measured number.
By their numbers in this assay, from the lowest: compounds 1, 2 and 3 (each within the scatter of the next, the first and the last beyond it).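

In this assay, the larger 1,2,3,4-tetrahydroisoquinolin-2-yl takes the place of pyrrolidin-1-yl on the aromatic carbon next to the ring nitrogen, and the result is a number 2.1 percentage points higher from compound 2 to compound 3 (within the scatter) on the shared core, so at this position the two rings cannot be told apart, despite the added six-membered aromatic ring of carbon only. With 1,2,3,4-tetrahydroisoquinolin-2-yl held constant, the exchange of the group on the oxygen gives a number 11.4 percentage points higher from compound 1 to compound 3 (beyond the scatter) even though the two groups have the same atom and ring counts, which makes this the only step shown so far that clears the scatter, and a modest one. Nothing available explains either step.

As far as these compounds go, whether a morpholine ring, a piperazine ring or an open-chain amine such as dimethylamino on the same aromatic carbon would move the reading beyond the scatter remains open. Also open, from the compounds shown here alone, is whether pyrrolidin-1-yl would behave on the core of compound 1 as it does on the core of compound 2, which would show if the effect of the oxygen-linked group holds with a different ring at the other position.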